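This account rests on a few compounds, and the source may have more. Where it says the series, first, only, none or still open, it means among the compounds named here.

Measured so far in a functional assay on A2780 cells (Homo sapiens) for antiproliferative activity, read by resazurin assay, with a stated time of 72 h; a lower number here means a stronger inhibitor, a higher number a weaker inhibitor:
compound 1 `CCCN(C)C(=O)c1cc2c(Cc3ccccc3)n[nH]c2cc1O` — > 10000 nM, a limit of the assay rather than a number.
compound 2 `CN(C(=O)c1cc2c(Cc3ccccc3)n[nH]c2cc1O)c1ccco1` — 2500 nM.

Compound 2 holds the only number shown in this assay; the other value is a limit. Going by the values given here, the single measured step, an at least 4.0-fold lower number from compound 1 to compound 2 (0.60 log units; beyond the scatter), is the only comparison at hand, and one end of it rests on (the limit of > 10000 nM in this assay, at which 1 of the 2 values shown sits), so its true size is not pinned down. Compound 3 `CN(Cc1cccc(F)c1)C(=O)c1cc2c(Cc3ccccc3)n[nH]c2cc1O` differs from compound 2 in one place: 3-fluorobenzyl in place of furan-2-yl on an amide-type nitrogen. Among the compounds with values here, no measured step swaps one aromatic group for another on the amide-type nitrogen, so the propyl-to-furan-2-yl step bears on this change only loosely. Nothing in the numbers points to a shift beyond the scatter, and the step is therefore estimated as a 1.3-fold lower number from compound 2 to compound 3 (0.10 log units; within the scatter). Compound 3 is expected to give about 2000 nM, between 600 nM and 7000 nM.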

Compound 3, half-maximal inhibitory concentration: 5000 nM
Estimate against measurement, compound 3: 2.5-fold (0.40 log units) below, within the range that was stated.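

The step on the amide-type nitrogen gives a 2.0-fold higher number from compound 2 to compound 3 (0.30 log units; within the scatter), so compound 2 and compound 3 cannot be told apart in this assay. As far as these two compounds go, a six-membered aromatic ring of carbon only, in 3-fluorobenzyl, serves on this nitrogen as well as the five-membered aromatic ring with 1 hetero atom in furan-2-yl. The comparison with the propyl amide reads as an at least 2.0-fold lower number from compound 1 to compound 3 (0.30 log units; that floor lies within the scatter), and one end of it is a limit of the assay rather than a number, so its true size stays open: the limit of > 10000 nM in this assay, at which 1 of the 3 values shown sits.

Whether the fluorine plays any part is open, since plain benzyl is not among the compounds shown. Also open, as far as these compounds go, is how a carboxylic acid or an amine on a chain at this nitrogen would compare with compound 2 and compound 3.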